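A few compounds are considered here, and "the series" means these few. Any claim that something is new, unique, unknown or untested is made for them only; others in the source may bear on it.

Compound 1 `Cc1ccc(NC(=O)Nc2ccc(N3C(=O)C4CC=CCC4C3=O)cc2)cc1C` gives < 35% in an assay on isolated protein for inhibition of metabotropic glutamate receptor 5 (Homo sapiens), tested at 10 uM; a lower number here means less inhibition, a higher number more inhibition at the concentration tested (going by the name of the read-out).
Compound 2 `Cc1ccc(NCC(=O)Nc2ccc(N3C(=O)C4CC=CCC4C3=O)cc2)cc1C` gives < 35% in this assay.
Compound 3 `Cc1ccc(OCCNC(=O)c2ccc(N3C(=O)C4CC=CCC4C3=O)cc2)cc1C` gives < 35% in this assay.

Each of these three values is a limit of the assay rather than a number. Compound 3 therefore stands at the limit of < 35% in this assay, at which 3 of the 3 values shown sit. Among the measured compounds shown here, the only pair of measured compounds that differ in one place is compound 1 and compound 2, and their step that the two limits leave unreadable from compound 1 to compound 2 cannot be read, since both of its ends are limits. For the measured compounds named here, no measured step, then, gives a readable size against which the next change could be weighed.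

Compound 4 `Cc1ccc(OCCCNC(=O)c2ccc(N3C(=O)C4CC=CCC4C3=O)cc2)cc1C` differs from compound 3 by (3,4-dimethylphenoxy)methyl in place of 3,4-dimethylphenoxy on a saturated chain carbon, two bonds along the chain from an amide-type nitrogen. This lengthens the chain by one saturated carbon, much as compound 2 lengthens the linker of compound 1, but that step is unreadable and nothing else in the set speaks to it. Going by the values given here, with all three measured compounds sitting at the limit and no step of any readable size, the expectation is that the change produces no effect that rises out of the scatter, and that compound 4 stays at the limit as well. Compound 4 is expected to give 15% in this assay, most likely between 0% and 35%. The step this estimate implies, a step that the limit leaves unreadable from compound 3 to compound 4, is expected to be no more than scatter.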

Compound 4, a percentage reported as inhibition, at one concentration (the size of the read-out at that concentration, not a potency): < 35%
Compound 4 ended at the assay's limit (the forecaster's own chance of this, stated with the estimate: 85%); the middle value is on the limit's open side.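

Among the compounds shown here, compound 4, like compound 3, sits at a limit of this assay rather than at a number, so no step between these two compounds can be read: the limit of < 35% in this assay, at which 4 of the 4 values shown sit.

The compounds shown leave open how strongly any of them inhibits the receptor, and whether any change to the linker moves the read-out at all.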